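A triazole in place of a methylsulfonyl on the aniline

The source may report more compounds than this note shows. Statements on the series, on what has been measured and on what is new or still open speak of the compounds shown alone.

Of the compounds shown here, two have been measured in an assay on isolated protein for inhibition of MAP/microtubule affinity-regulating kinase 3 (Homo sapiens); a higher number here means a weaker inhibitor, a lower number a stronger inhibitor. Compound 1 `C[C@H](c1ccc(F)cc1)N1C(=O)C(C)(C)c2cnc(Nc3cccnc3)nc21` gives 1520 nM. Compound 2 `CC[C@H](C)N1C(=O)C(C)(C)c2cnc(Nc3ccc(S(C)(=O)=O)cc3)nc21` gives 120 nM, the lower of the two numbers; the gap to compound 1 lies well beyond the usual scatter. Compound 3 `CC[C@H](C)N1C(=O)C(C)(C)c2cnc(Nc3ccc(-c4nnc(C)[nH]4)cc3)nc21` keeps the core of compound 2 and alters only the group on the aniline ring: 5-methyl-4H-1,2,4-triazol-3-yl in place of methylsulfonyl on an aromatic carbon. Among the compounds with values here, no measured pair shows this exact exchange, so no step can be quoted for it, and the expectation rests on the single strong number of compound 2 together with the nature of the swap. Compound 3 is expected to stay close to compound 2, at an estimated 100 nM with a plausible range from 30 nM to 400 nM. This estimate means a step of a 1.2-fold lower number from compound 2 to compound 3 (0.08 log units; within the scatter), which is expected to sit within the scatter rather than beyond it.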

Compound 3, half-maximal inhibitory concentration: 80 nM
For compound 3 the middle estimate is 1.3-fold (0.10 log units) above the measured one, within the range that was stated.
By their numbers in this assay, from the lowest: compounds 3 and 2 (each within the scatter of the next); then compound 1.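

In this assay, putting 5-methyl-4H-1,2,4-triazol-3-yl in place of methylsulfonyl gives a 1.5-fold lower number from compound 2 to compound 3 (0.18 log units; within the scatter), so the two compounds cannot be told apart in this test. This position on the aniline ring, para to a large group, is therefore not tied to methylsulfonyl: a five-membered aromatic ring with 1 hydrogen-bond donor, which methylsulfonyl lacks, reads the same here. The data offer no measurement that explains why two such different groups read alike.

On these data alone, it remains open whether either group contributes at all, as a plain hydrogen at this position would show. As far as these compounds go, it is also open whether an amine, a carboxylic acid or a simple amide placed here would read alike or would separate clearly from these two.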